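This account rests on a few compounds, and the source may have more. Where it says the series, first, only, none or still open, it means among the compounds named here.

Measured so far in a toxicity assay on L02 cells (Homo sapiens) for cytotoxicity, read by MTT assay, with a stated time of 72 h; a lower number here means a stronger inhibitor, a higher number a weaker inhibitor:
Compound 1, `CN1CCN(CCCCCn2c3c(c4ccccc42)C(=O)c2c[n+]([O-])c4ccccc4c2C3=O)CC1`, gives 1640 nM.
Compound 2, `O=C1c2c[n+]([O-])c3ccccc3c2C(=O)c2c1c1ccccc1n2Cc1cn(CC(O)CO)nn1`, gives 1070 nM.
Compound 3, `CN(C)CCCCn1c2c(c3ccccc31)C(=O)c1c[n+]([O-])c3ccccc3c1C2=O`, gives 300 nM.

Compound 3 has the lowest number of the three, and its steps to both neighbours lie beyond the scatter: a 3.6-fold lower number from compound 2 to compound 3 (0.55 log units; beyond the scatter) and a 5.5-fold lower number from compound 1 to compound 3 (0.74 log units; beyond the scatter). Compound 4, `CN1CCN(CCCCn2c3c(c4ccccc42)C(=O)c2c[n+]([O-])c4ccccc4c2C3=O)CC1`, is the next compound. The change is 4-methylpiperazin-1-yl in place of dimethylamino on a saturated chain carbon, four bonds along the chain from an aromatic nitrogen. Among the measured compounds shown here, the only measured step that bears on this change is the one from compound 1 to compound 3, a 5.5-fold lower number from compound 1 to compound 3 (0.74 log units; beyond the scatter), which ran the same swap in reverse on a chain one carbon longer. A modest rise in the number is therefore expected for compound 4, a 4.0-fold higher number from compound 3 to compound 4 (0.60 log units; beyond the scatter). Compound 4 is estimated at 1200 nM, with a range from 500 nM to 2800 nM.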

Compound 4, half-maximal inhibitory concentration: 80 nM
Estimate against measurement, compound 4: 15-fold (1.18 log units) above; measured number below the stated range.
By their numbers in this assay, from the lowest: compound 4; then compound 3; then compounds 2 and 1 (each within the scatter of the next).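

In this assay, 4-methylpiperazin-1-yl in place of dimethylamino gives a 3.8-fold lower number from compound 3 to compound 4 (0.57 log units; beyond the scatter), so this swap lowers the number on this chain, while the same pair of groups ran the other way on the chain one carbon longer, with a 5.5-fold lower number from compound 1 to compound 3 (0.74 log units; beyond the scatter). Shortening that chain by one carbon while keeping the piperazine gives a 21-fold lower number from compound 1 to compound 4 (1.31 log units; beyond the scatter), and replacing the triazole-bearing group gives a 13-fold lower number from compound 2 to compound 4 (1.13 log units; beyond the scatter), so the chain length and the amine must be read together. No available evidence explains these steps.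

From the compounds shown here alone, a morpholine ring at the chain end remains open, as does a shorter chain carrying 4-methylpiperazin-1-yl.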